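Sulfonyl aryl exchange from compound 2 to compound 3

The source may report more compounds than this note shows. Statements on the series, on what has been measured and on what is new or still open speak of the compounds shown alone.

Going by the values given here, in a functional assay on VCaP cells (Homo sapiens) for antiproliferative activity, read by propidium iodide staining, with a stated time of 96 h (on this read-out lower numbers stand for stronger inhibition and higher numbers for weaker inhibition), compound 2 (`CC(O)(CS(=O)(=O)c1ccc(F)cc1)C(=O)Nc1cccc(S(F)(F)(F)(F)F)c1`) gives 37900 nM and holds the higher of the two numbers so far, with compound 1 (`CC(O)(CS(=O)(=O)c1ccc(S(F)(F)(F)(F)F)cc1)C(=O)Nc1cccc(S(F)(F)(F)(F)F)c1`) at 17200 nM on the same read-out. Among the compounds with values here, the one measured step is a 2.2-fold higher number from compound 1 to compound 2 (0.34 log units; beyond the scatter) as a single fluorine atom replaces a larger group on an aromatic carbon. It is modest but beyond the scatter. Compound 3 (`CC(O)(CS(=O)(=O)c1cccc(OC(F)(F)F)c1)C(=O)Nc1cccc(S(F)(F)(F)(F)F)c1`) brings 3-(trifluoromethoxy)phenyl in place of 4-fluorophenyl on a sulfonyl sulfur with 3-(trifluoromethoxy)phenyl in place of 4-fluorophenyl on a sulfonyl sulfur. Within the data shown here, no measured compound carries this group, so the guidance is thin. With compound 1 and its step of a 2.2-fold higher number from compound 1 to compound 2 (0.34 log units; beyond the scatter) as the only reference, a small move toward a lower number is expected, perhaps not beyond the scatter. The estimated 1.6-fold lower number from compound 2 to compound 3 (0.20 log units; within the scatter) is therefore no larger than that measured step. For compound 3 the estimate is 24000 nM (expected range 9000 nM to 60000 nM).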

Compound 3, half-maximal inhibitory concentration: 20200 nM
For compound 3 the middle estimate is 1.2-fold (0.07 log units) above the measured one; low and high end bracket the measured number.
By their numbers in this assay, from the lowest: compounds 1, 3 and 2 (each within the scatter of the next, the first and the last beyond it).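

In this assay, a 1.9-fold lower number from compound 2 to compound 3 (0.27 log units; within the scatter) shows that on the sulfonyl sulfur, 3-(trifluoromethoxy)phenyl can stand in place of 4-fluorophenyl without a step beyond the scatter, despite the higher heavy-atom count and the added hydrogen-bond acceptor. Compound 3 also lies within the scatter of both compound 1 and compound 2, while those two remain apart, so the three compounds no longer form two clearly separated values. Nothing at hand accounts for this result.

The compounds shown leave open whether an aryl ring carrying an amine or a carboxylic acid, or a saturated ring in place of the aryl group, would produce a step beyond the scatter on the sulfonyl sulfur. They also leave open how changes elsewhere in the shared core would read out in this assay.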